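Hydroxy on the saturated ring of compound 2

A few compounds are considered here, and "the series" means these few. Any claim that something is new, unique, unknown or untested is made for them only; others in the source may bear on it.

In an ADME assay for permeability, using PAMPA, at pH 6.5 (a higher number here means that the compound crosses the layer faster, a lower number that the compound crosses the layer more slowly), compound 2 `Cc1ccccc1-n1nc(-c2c(-c3ccc(F)cc3)nn3c2NCCC3)ccc1=O` reads 30 10^-6 cm/s and compound 1 `Cc1ccccc1-n1nc(-c2c(-c3ccc(F)cc3)nn(C)c2NCCCO)ccc1=O` reads 17 10^-6 cm/s with the two values inside the scatter of each other. Compound 3 `Cc1ccccc1-n1nc(-c2c(-c3ccc(F)cc3)nn3c2OCCC3)ccc1=O` has the entry "not determined" (no result reported) and offers no number for comparison. Compound 4 `Cc1ccccc1-n1nc(-c2c(-c3ccc(F)cc3)nn3c2NC[C@@H](O)C3)ccc1=O` departs from compound 2 by one change: hydroxy in place of hydrogen on a saturated ring carbon. For the measured compounds named here, no measured pair shows this change on its own. Compound 1, which also carries a hydroxy group, reads 17 10^-6 cm/s in this assay and that number keeps the expectation moderate. A fall somewhat beyond the scatter is expected, with a 2.5-fold lower number from compound 2 to compound 4 (0.40 log units; beyond the scatter) as the estimated step. For compound 4 the estimate is 12 10^-6 cm/s with an expected range from 5 10^-6 cm/s to 25 10^-6 cm/s in this assay for now.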

Compound 4, apparent permeability: 16 10^-6 cm/s
For compound 4 the middle estimate is 1.3-fold (0.12 log units) below the measured one, and the stated range covers the measured number.
By their numbers in this assay, from the lowest: compounds 4, 1 and 2 (each within the scatter of the next).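

In this assay, hydroxy in place of hydrogen on a saturated ring carbon gives a 1.9-fold lower number from compound 2 to compound 4 (0.27 log units; within the scatter), so this position takes the hydroxy without a step beyond the scatter. This is the only pair shown that isolates the change, as compound 1 differs from compound 2 in more than one place. Nothing measured here bears on why the step has this size. Still open, on these data alone, is whether the opposite stereoisomer at this carbon, or an amine or a methoxy group in the same place, would read alike in this assay.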